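The compounds below may be only part of what the source reports. "The series", "measured", "known", "first", "only" and "open" are said of these compounds alone.

The series shares one core, differing in the amine attached to it and in the ring on the other side. In a functional assay on MCF7 cells (Homo sapiens) for inhibition, read by CCK-8 assay, with a stated time of 48 h (a higher number here means a weaker inhibitor of growth, a lower number a stronger inhibitor of growth), compound 1 `Cc1ccccc1Nc1nc(Nc2cc(Cl)ccn2)ncc1Cl` reaches only a limit, recorded as > 100000 nM. Compound 2 `Cc1ccccc1Nc1nc(Nc2ccc(N3CCNCC3)cn2)ncc1Cl` gives 3410 nM in this assay. Compound 3 `CN1CCN(c2ccc(Nc3ncc(Cl)c(NCc4ccccc4)n3)nc2)CC1` gives 17300 nM in this assay, the higher of the two numbers reported, with compound 2 below it by more than the usual scatter. The remaining entry, that of compound 1, is a limit rather than a number, sitting at the limit of > 100000 nM in this assay, at which 1 of the 3 values shown sits.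

Compound 4 `CCc1ccc(Nc2nc(Nc3ccc(N4CCN(C)CC4)cn3)ncc2Cl)cc1` has not yet been measured. It differs from compound 3 in one place 4-ethylphenyl in place of benzyl on a nitrogen on an aromatic ring: 4-ethylphenyl takes the place of benzyl on a nitrogen on an aromatic ring whose other neighbour is an aromatic carbon. Among the compounds with values here, no measured pair isolates this change, so the expected step rests on compound 2, which carries an arylamine at the same nitrogen and gives 3410 nM in this assay. A downward step, beyond the scatter, is expected, of the size a 4.3-fold lower number from compound 3 to compound 4 (0.64 log units; beyond the scatter). Compound 4 is therefore estimated at 4000 nM in this assay, within a range from 1000 nM to 15000 nM.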

Compound 4, concentration for 50% growth inhibition: 8230 nM
Estimate against measurement, compound 4: 2.1-fold (0.31 log units) below, within the range that was stated.
By their numbers in this assay, from the lowest: compound 2; then compound 4; then compound 3. At a limit, above all of these: compound 1.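

Within the data shown here, replacing benzyl with 4-ethylphenyl on a nitrogen on an aromatic ring is the first change at this position that a measured pair isolates: in this assay it gives a 2.1-fold lower number from compound 3 to compound 4 (0.32 log units; beyond the scatter). The step is modest but beyond the scatter, so this position does respond to the change, and here the group with its aromatic ring directly on the nitrogen carries the lower number. Nothing among the data shown gives a reason for this step.

From the compounds shown here alone, it remains open what part the ethyl group plays, as an unsubstituted phenyl, a longer chain such as butyl, an amine or a carboxylic acid in its place could move the number either way. Going by these compounds, whether the step would hold with a fluorine in place of the chlorine on the shared core also remains open.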